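A few compounds are considered here, and "the series" means these few. Any claim that something is new, unique, unknown or untested is made for them only; others in the source may bear on it.

Compound 1 `OCCNc1nc(-c2ccccc2)nc2c1nnn2Cc1ccccc1`, compound 2 `CCCCNc1nc(-c2ccccc2)nc2c1nnn2Cc1ccccc1` and compound 3 `CCCCNc1nc(-c2ccccc2)nc2c1nnn2Cc1ccccc1F` share one core. In an assay on isolated protein for binding affinity to adenosine receptor A1 (Bos taurus) (a lower number here means a stronger inhibitor, a higher number a weaker inhibitor), compound 1 gives 38000000 nM, compound 2 gives 11000000 nM and compound 3 gives 4300000 nM; compound 2 thus stands second highest of the three. Compound 4 `O[C@H]1CCCC[C@@H]1Nc1nc(-c2ccccc2)nc2c1nnn2Cc1ccccc1` is not yet measured; its change from compound 2 is 2-hydroxycyclohexyl in place of butyl on a nitrogen on an aromatic ring. The step of a 3.5-fold lower number from compound 1 to compound 2 (0.54 log units; beyond the scatter) is the one that bears on it, since there the hydroxy left the chain and the number fell; here a hydroxy returns, now on a ring. A modest rise is therefore expected, a 2.0-fold higher number from compound 2 to compound 4 (0.30 log units; within the scatter). Compound 4 is estimated at 22000000 nM, within 6000000 nM to 80000000 nM.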

Compound 4, inhibition constant: 10300000 nM
For compound 4 the middle estimate is 2.1-fold (0.33 log units) above the measured one; measured number inside the range.
By their numbers in this assay, from the lowest: compound 3; then compounds 4 and 2 (each within the scatter of the next); then compound 1.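

At this position, on a nitrogen on an aromatic ring, a much larger group that carries a hydroxy and a ring still leaves the number level with butyl, with a 1.1-fold lower number from compound 2 to compound 4 (0.03 log units; within the scatter) here. A hydroxy alone therefore does not tie a compound to the high number of compound 1, since a 3.7-fold lower number from compound 1 to compound 4 (0.57 log units; beyond the scatter) while both groups keep it. Nothing available explains these results.

On these data alone, whether the ring, the hydroxy or both shape this outcome stays open. Plain cyclohexyl on that nitrogen would separate the two, and the opposite arrangement at the two stereocentres is also unknown.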